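Swapping a Carbamate for an Aryl Urea

The source may hold more compounds than are shown below. What is called first, only, known or untested is meant among the compounds shown, and "the series" means these compounds.

Of the compounds shown here, three have been measured in a functional assay on Shh Light II cells (Mus musculus) for inhibition, read by a luciferase reporter; a higher number here means a weaker inhibitor, a lower number a stronger inhibitor. Compound 1 `O=C(NC1CCCCC1)N1CCN(c2nc(-c3ccc4ccccc4n3)no2)CC1` gives 53 nM, compound 3 `Cn1c(-c2noc(N3CCN(C(=O)NC4CCCCC4)CC3)n2)nc2ccccc21` gives 5 nM, and compound 2 `O=C(OC1CCCCC1)N1CCC(c2nc(-c3ccc4ccccc4n3)no2)CC1` gives 580 nM, the highest of the three numbers and so the weakest inhibitor of the set, its gaps to the other two lying beyond the scatter. Compound 4 `Cc1ccccc1NC(=O)N1CCC(c2nc(-c3ccc4ccccc4n3)no2)CC1` differs from compound 2 in one place: (2-methylphenyl)amino in place of cyclohexyloxy on a carbonyl carbon. Among the compounds with values here, the only step measured so far, an 11-fold lower number from compound 1 to compound 3 (1.03 log units; beyond the scatter), changes a different part of the molecule and does not bear on this swap. Compound 1 and compound 2 differ both at this carbonyl and in the ring carrying it, so their values only hint that a nitrogen-linked group on the carbonyl may go with a lower number. On that hint, compound 4 is expected to give 200 nM, within 50 nM to 800 nM. The expected step is a 2.9-fold lower number from compound 2 to compound 4 (0.46 log units; beyond the scatter), modest in size.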

Compound 4, half-maximal inhibitory concentration: 440 nM
Compound 4: the middle estimate sits 2.2-fold (0.34 log units) below what was measured; the measured number falls inside the stated range.
By their numbers in this assay, from the lowest: compound 3; then compound 1; then compounds 4 and 2 (each within the scatter of the next).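

In this assay putting (2-methylphenyl)amino in place of cyclohexyloxy on this carbonyl carbon gives a 1.3-fold lower number from compound 2 to compound 4 (0.12 log units; within the scatter) and so does not separate the two groups on this core. A nitrogen-linked group here, with its amide hydrogen and aromatic ring, therefore brings no measurable gain over the oxygen-linked cyclohexyl group. Nothing available explains this result. Still open, on these data alone, is whether a cyclohexylamino group on this carbonyl would give a different number on the core of compound 2. A plain phenylamino group, without the methyl, also remains to be compared with (2-methylphenyl)amino.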